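A few compounds are considered here, and "the series" means these few. Any claim that something is new, unique, unknown or untested is made for them only; others in the source may bear on it.

Measured compounds:
- compound 1, `N=C(N)c1ccc(-c2ccc(-c3ccc(F)cc3)o2)o1`: 17.6%
- compound 2, `N=C(N)c1ccc(-c2ccc(-c3ccc4ccccc4c3)s2)s1`: "non-toxic" (no number reported)
- compound 3, `N=C(N)c1ccc(-c2ccc(-c3cc(Cl)cc(Cl)c3)o2)o1`: 11.1%

All three share the same core and differ only in the outer aromatic ring. They were tested in an ADME assay on cells (Erythrocyte, Homo sapiens) for activation, read by hemolysis, with a stated time of 30 min, tested at 2.5 mM; on this read-out lower numbers stand for a weaker effect and higher numbers for a stronger effect at the one concentration tested. Compound 1 gives 17.6% and compound 3 gives 11.1%; these two numbers sit within the usual scatter of each other, so neither compound can be said to act more strongly on the red cells than the other. For compound 2 only the word non-toxic was reported, without a number, so it cannot be placed against the other two on a scale.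

Compound 4, `N=C(N)c1ccc(-c2ccc(-c3ccccc3)o2)o1`, is the next compound in line and has not yet been measured in this assay. It differs from compound 1 in one place: hydrogen in place of fluoro on an aromatic carbon. Going by the values given here, no pair of measured compounds shows the effect of such a change on this read-out, so there is nothing to lean on beyond the values of compound 1 and compound 3, which themselves do not separate. The expectation is therefore a step of a number 2.6 percentage points lower from compound 1 to compound 4 (within the scatter), that is, no shift beyond the scatter in either direction. Compound 4 is accordingly expected to give about 15% in this assay, with a range from 5% to 28%.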

Compound 4, a percentage reported as activity, at one concentration (the size of the read-out at that concentration, not a potency): 7%
The estimate for compound 4 lay 8 percentage points above the measured number; measured number inside the range.
By their numbers in this assay, from the lowest: compounds 4, 3 and 1 (each within the scatter of the next, the first and the last beyond it).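

Hydrogen in place of fluoro on an aromatic carbon, para to a large group, is the first change in this set made at a single place, and in this assay it gives a number 10.6 percentage points lower from compound 1 to compound 4 (beyond the scatter). The earlier compounds shown here could not show this, as no two of them differed in one place only; this step shows that the position is not indifferent to what sits on it, since the loss of one fluorine atom, with the rest of the structure unchanged, is enough to move the read-out, though only modestly. Nothing measured here explains why this change moves the number.

From the compounds shown here alone, a single step gives one direction at one position, so it remains open whether the fluoro group is special here or whether another small group, such as chloro, methoxy or an amine, would give a similar number in this assay. Going by these compounds, it also remains open whether the same exchange would give a step of similar size on the core of compound 2, which carries no number to compare.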